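A few compounds are considered here, and "the series" means these few. Any claim that something is new, unique, unknown or untested is made for them only; others in the source may bear on it.

Within the data shown here, in a functional assay on HEL cells (Homo sapiens) for inhibition (a lower number here means a stronger inhibitor, a higher number a weaker inhibitor), compound 2 (`CC(C)c1cc(-c2n[nH]c(=O)n2-c2ccc(C(=O)NCCCCCCCC(=O)NO)cc2)c(O)cc1O`) gives 4600 nM, the higher of the two numbers so far, while compound 1 (`CC(C)c1cc(-c2n[nH]c(=O)n2-c2cccc(NC(=O)CCCCCC(=O)NO)c2)c(O)cc1O`) gives 1600 nM, a gap beyond the scatter. Compound 3 (`CC(C)c1cc(-c2n[nH]c(=O)n2-c2ccc(C(=O)NCCCC(=O)NO)cc2)c(O)cc1O`) is not yet measured. It differs from compound 2 by hydroxycarbamoyl in place of 4-(hydroxycarbamoyl)butyl on a saturated chain carbon, three bonds along the chain from an amide-type nitrogen. Among the measured compounds shown here, no measured pair differs in one place, so the expectation rests on this structural change alone. In this assay the expected step is a 2.2-fold higher number from compound 2 to compound 3 (0.34 log units; beyond the scatter), a moderate rise towards weaker inhibition. Compound 3 is estimated at 10000 nM, with an expected range of 3000 nM to 35000 nM.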

Compound 3, half-maximal inhibitory concentration: 4600 nM
Beside the measured number, compound 3's estimate is 2.2-fold (0.34 log units) above it, within the range that was stated.
By their numbers in this assay, from the lowest: compound 1; then compounds 2 and 3 (each within the scatter of the next).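

In this assay, replacing 4-(hydroxycarbamoyl)butyl with hydroxycarbamoyl on a saturated chain carbon, three bonds along the chain from an amide-type nitrogen, gives no change at the digits printed from compound 2 to compound 3 (within the scatter). Among these compounds, this is the first one-place comparison, and over this span the assay does not separate the 7-(hydroxycarbamoyl)heptyl chain from the 3-(hydroxycarbamoyl)propyl chain. Nothing available explains this result. Open, as far as these compounds go, is whether a longer chain, or one shorter than 3-(hydroxycarbamoyl)propyl, changes the number. Also open, from the compounds shown here alone, is how a carboxylic acid in place of the hydroxycarbamoyl end behaves at this position.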